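The source may hold more compounds than are shown below. What is called first, only, known or untested is meant among the compounds shown, and "the series" means these compounds.

Compound 1, `O=C(O)c1cccc(CNc2cc(C(F)(F)F)cc3[nH]ncc23)c1`, with 94% in an assay for inhibition of Tryptophan 2,3-dioxygenase (Homo sapiens), with stated times of 10 min and 60 min, tested at 100 uM; a lower number here means a weaker effect, a higher number a stronger effect of the compound at the concentration tested; compound 2, `O=[N+]([O-])c1ccc(CNc2cc(C(F)(F)F)cc3[nH]ncc23)cc1`, with 64% in this assay.

Among the two compounds measured in this assay, compound 1 stands highest: its number lies above that of compound 2 by a gap beyond the usual scatter of this kind of measurement. Compound 3, `FC(F)(F)c1cc(NCc2cccc(Br)c2)c2cn[nH]c2c1`, has not been measured yet. It differs from compound 1 in one place: bromo in place of carboxy on an aromatic carbon, on an aromatic carbon of a six-membered aromatic ring of carbon only, meta to a large group. The carboxy group that leaves brings one hydrogen-bond donor and one hydrogen-bond acceptor; the bromo group that enters brings neither. Among the compounds with values here, no pair of measured compounds shows this exact exchange, so the step has no precedent among the data. Compound 2, in which the same aromatic ring carries a nitro group instead, gives 64%. On that basis compound 3 is expected to show a downward step of a number 29 percentage points lower from compound 1 to compound 3 (beyond the scatter), beyond the scatter. The estimate for compound 3 in this assay is 65%, within a range of 35% to 90%.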

Compound 3, a percentage reported as inhibition, at one concentration (the size of the read-out at that concentration, not a potency): 84%
Compound 3: middle estimate off by 19 percentage points, on the low side; the range from low to high includes it.
By their numbers in this assay, from the lowest: compound 2; then compounds 3 and 1 (each within the scatter of the next).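

In this assay the exchange of carboxy for bromo on an aromatic carbon, meta to a large group, gives a number 10 percentage points lower from compound 1 to compound 3 (within the scatter) and so does not separate the two groups. The carboxy group, with its hydrogen-bond donor and acceptor, is therefore not required at this position for a high read-out at the single concentration tested: compound 3, which carries a lone bromine atom and neither donor nor acceptor, gives 84% in this comparison with compound 1. Nothing in the data bears on why these two different groups read alike.

As far as these compounds go, whether an amine, a primary amide, a methyl ester or a chloro group on this same aromatic carbon would also read like carboxy and bromo remains open. Also open, from the compounds shown here alone, is whether compound 1 and compound 3 would stay as close at lower concentrations, since a read-out at one concentration is not a potency and cannot settle how the two compare across a full concentration range.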